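Replacing the pyridinylmethyl arm with a chlorophenyl cyclopropyl group

The compounds below may be only part of what the source reports. "The series", "measured", "known", "first", "only" and "open" are said of these compounds alone.

Going by the values given here, compound 2 `COc1cc(C(=O)N2CCC(O)C(C)C2)cc2nc(NCc3cc(Cl)ccn3)oc12` has the lowest of the two numbers so far in an assay on isolated protein for inhibition of thyroid hormone receptor beta (Homo sapiens), read by fluorescence, with a stated time of 30 min (a lower number here means a stronger inhibitor, a higher number a weaker inhibitor), giving 190 nM; compound 1 `COc1cc(C(=O)N2CCC(O)CC2)cc2nc(NCc3cccc(Cl)c3)oc12` gives 352 nM, a gap within the scatter, so the two stand level. Compound 3 `COc1cc(C(=O)N2CCC(O)C(C)C2)cc2nc(NC3(c4cccc(Cl)c4)CC3)oc12` differs from compound 2 by 1-(3-chlorophenyl)cyclopropyl in place of (4-chloropyridin-2-yl)methyl on a nitrogen on an aromatic ring. Among the compounds with values here, no measured pair shows this change, so neither size nor direction can be read from the numbers. For compound 3 the expected step is a 1.4-fold higher number from compound 2 to compound 3 (0.14 log units; within the scatter), nothing beyond the scatter in either direction. Compound 3 is estimated at 260 nM, with a range from 80 nM to 850 nM.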

Compound 3, half-maximal inhibitory concentration: 120 nM
Compound 3: middle estimate off by 2.2-fold (0.34 log units), on the high side, within the range that was stated.
By their numbers in this assay, from the lowest: compounds 3, 2 and 1 (each within the scatter of the next, the first and the last beyond it).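

In this assay, 1-(3-chlorophenyl)cyclopropyl in place of (4-chloropyridin-2-yl)methyl on a nitrogen on an aromatic ring gives a 1.6-fold lower number from compound 2 to compound 3 (0.20 log units; within the scatter), so compound 2 and compound 3 stand level. This position therefore accepts an arm with a three-membered carbon ring and no ring nitrogen, with the number staying within the scatter. Nothing measured here gives a reason for this result. The step changes the aromatic ring and the link to the nitrogen together, so the contribution of each remains unseparated. Going by these compounds, how a cyclobutyl ring or an amine on this arm would read remains open.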